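This account rests on a few compounds, and the source may have more. Where it says the series, first, only, none or still open, it means among the compounds named here.

Working notes on the series. In an ADME assay on Huh-7 cells (Homo sapiens) for cytotoxicity (a higher number here means that more compound is tolerated, a lower number that less compound is tolerated), compound 1 `COc1ccc(C(=O)NC(=S)N2CCc3c(OCCCCCOc4ccc(Cl)cc4)cccc32)cc1` gives 34400 nM. Compound 2 `CC(C)(C)c1ccc(C(=O)NC(=S)N2CCc3c(OCCCCCOc4ccc(Cl)cc4)cccc32)cc1` returns only a limit of the assay, > 50000 nM. Compound 3 `O=C(NC(=S)N1CCc2c(OCCCCCOc3ccc(Cl)cc3)cccc21)c1ccc2ccccc2c1` likewise returns only a limit, > 50000 nM; because of the limit of > 50000 nM in this assay, at which 2 of the 3 values shown sit, compound 3 cannot be placed more closely than that. Compound 4 `S=C(NC(=S)N1CCc2c(OCCCCCOc3ccc(Cl)cc3)cccc21)Oc1ccccc1` differs from compound 3 by a group of 9 heavy atoms (7 carbon, 1 oxygen, 1 sulfur; one six-membered aromatic ring of carbon only) in place of a group of 12 heavy atoms (11 carbon, 1 oxygen; 2 six-membered aromatic rings of carbon only), on an amide-type nitrogen. The measured steps that bear on it are an at least 1.4-fold higher number from compound 1 to compound 3 (0.16 log units; that floor lies within the scatter) and a step that the two limits leave unreadable from compound 2 to compound 3, neither of which gives a direction beyond the scatter. How a smaller group on the amide-type nitrogen shifts tolerance is therefore not readable from these values. Compound 4 is expected near 45000 nM, between 15000 nM and 150000 nM. This estimate means an at least 1.1-fold lower number from compound 3 to compound 4 (0.04 log units; that floor lies within the scatter), expected to stay within the scatter.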

Compound 4, half-maximal cytotoxic concentration: > 50000 nM
Compound 4: a limit, no number; the forecaster's own chance of this, stated with the estimate: 50%; middle value at least 1.1-fold (0.04 log units) from the limit.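

Compound 4 returns only a limit in this assay, so a sulfur-bearing group on the amide-type nitrogen also gives no number. For the compounds shown here, the only readable step is an at least 1.4-fold higher number from compound 1 to compound 4 (0.16 log units; that floor lies within the scatter), which gives no direction beyond the scatter. The steps to compound 4 from compound 2 and compound 3 cannot be read because both ends of each are limits: the limit of > 50000 nM in this assay, at which 3 of the 4 values shown sit.

Still open, from the compounds shown here alone, is how far the true values of compound 2, compound 3 and compound 4 lie from that limit. Also open, going by these compounds, is whether an amine or a carboxylic acid in the group on this nitrogen would give a measurable number.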